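The source may hold more compounds than are shown below. What is called first, only, known or untested is meant among the compounds shown, and "the series" means these compounds.

Measured compounds:
compound 1, `COc1ccc(-c2cc3n(n2)CCN(Cc2ccc(Cl)nc2)C3=O)cc1` — > 64000 nM
compound 2, `O=C1c2cc(-c3ccc(Cl)cc3)nn2CCN1Cc1ccc(Cl)nc1` — 39500 nM
compound 3, `CCCCN1CCn2nc(-c3ccc(OC)cc3)cc2C1=O` — 62500 nM

In a functional assay on A549 cells (Homo sapiens) for inhibition, read by MTT assay, with a stated time of 48 h (on this read-out higher numbers stand for weaker inhibition and lower numbers for stronger inhibition), compound 1 gives only a limit of the assay, > 64000 nM (the limit of > 64000 nM in this assay, at which 1 of the 3 values shown sits). Compound 2 gives 39500 nM and compound 3 gives 62500 nM in this assay; these two values lie within the scatter of each other. From compound 1 to compound 2 the change is chloro in place of methoxy on an aromatic carbon, and the step is an at least 1.6-fold lower number from compound 1 to compound 2 (0.20 log units; that floor lies within the scatter). Compound 3 differs from compound 1 in the core: propyl in place of 6-chloropyridin-3-yl on a saturated chain carbon bound to an amide-type nitrogen in a ring, with an at least 1.0-fold lower number from compound 1 to compound 3 (0.01 log units; that floor lies within the scatter).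

Compound 4, `CCCCN1CCn2nc(-c3ccc(Cl)cc3)cc2C1=O`, is not yet measured. It differs from compound 3 by chloro in place of methoxy on an aromatic carbon, the same change as from compound 1 to compound 2, at the same place. Because an at least 1.6-fold lower number from compound 1 to compound 2 (0.20 log units; that floor lies within the scatter) lies within the scatter, the step from compound 3 to compound 4 is expected to be small, a 1.6-fold lower number from compound 3 to compound 4 (0.19 log units; within the scatter). Compound 4 is expected to give about 40000 nM, between 15000 nM and 100000 nM.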

Compound 4, half-maximal inhibitory concentration: 29800 nM
The estimate for compound 4 lay 1.3-fold (0.13 log units) above the measured number; the measured number falls inside the stated range.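

In this assay, chloro in place of methoxy gives a 2.1-fold lower number from compound 3 to compound 4 (0.32 log units; beyond the scatter), and its counterpart on the core of compound 1 can be read only as a floor: the same change on two cores in this assay, an at least 1.6-fold lower number (0.20 log units; that floor lies within the scatter) from compound 1 to compound 2 and a 2.1-fold lower number (0.32 log units; beyond the scatter) from compound 3 to compound 4; the limit leaves it open whether they differ. Propyl in place of 6-chloropyridin-3-yl gives a 1.3-fold lower number from compound 2 to compound 4 (0.12 log units; within the scatter), and its counterpart is also only a floor: the same change on two cores in this assay, an at least 1.0-fold lower number (0.01 log units; that floor lies within the scatter) from compound 1 to compound 3 and a 1.3-fold lower number (0.12 log units; within the scatter) from compound 2 to compound 4; the limit leaves it open whether they differ. Both comparisons rest on compound 1, which gives only a limit of the assay, so a lower number with chloro is seen on both cores, but equal step sizes are not shown: the limit of > 64000 nM in this assay, at which 1 of the 4 values shown sits.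

Still open, going by these compounds, is how a nitrile or a trifluoromethyl group in place of methoxy would read on either core. Also open, on these data alone, is whether an amine or a longer chain in place of propyl would move the number beyond the scatter.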